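From Phenyl to 4-Bromophenyl Against PC-3 Cells

A few compounds are considered here, and "the series" means these few. Any claim that something is new, unique, unknown or untested is made for them only; others in the source may bear on it.

- Compound 1 (`Cc1cccn2cc(-c3nnc(-c4ccc(N(C)C)cc4)o3)nc12`) gives 11600 nM
- Compound 2 (`COc1cc(-c2nnc(-c3cn4cccc(C)c4n3)o2)cc(OC)c1OC`) gives 10900 nM
- Compound 3 (`Cc1cc(Br)c2nc(-c3nnc(-c4ccccc4)o3)cn2c1`) gives 17800 nM

In a functional assay on PC-3 cells (Homo sapiens) for antiproliferative activity, read by MTT assay, with a stated time of 48 h (a higher number here means a weaker inhibitor, a lower number a stronger inhibitor), compound 3 (17800 nM) holds the highest of the three numbers, yet it lies within the scatter of both compound 1 and compound 2, so the three cannot be ranked. Compound 4 (`Cc1cc(Br)c2nc(-c3nnc(-c4ccc(Br)cc4)o3)cn2c1`) carries bromo in place of hydrogen on an aromatic carbon, para to a large group, turning phenyl to 4-bromophenyl (bromo in place of hydrogen on an aromatic carbon). Among the compounds with values here, no measured pair isolates this change. Compound 1 at 11600 nM and compound 2 at 10900 nM differ from compound 3 in more than one place, yet stay within its scatter. No change beyond the scatter is therefore expected in this assay. The estimated step is a 1.4-fold lower number from compound 3 to compound 4 (0.14 log units; within the scatter) and would stay within the scatter. The value expected for compound 4 is 13000 nM (estimated range 6000 nM to 28000 nM).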

Compound 4, half-maximal inhibitory concentration: 24500 nM
Beside the measured number, compound 4's estimate is 1.9-fold (0.28 log units) below it, within the range that was stated.
By their numbers in this assay, from the lowest: compounds 2, 1, 3 and 4 (each within the scatter of the next, the first and the last beyond it).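

In this assay, within the data shown here, bromo in place of hydrogen on an aromatic carbon, para to a large group, gives a 1.4-fold higher number from compound 3 to compound 4 (0.14 log units; within the scatter), the only step here that changes a single place. Turning phenyl to 4-bromophenyl thus stays within the scatter at this position, which the earlier compounds, differing in more than one place, could not show. Nothing measured here explains this small step. From the compounds shown here alone, whether a carboxylic acid or a nitrile on the same carbon would move the number beyond the scatter remains open.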